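A smaller aryl imine on a weakly active core

The source may report more compounds than this note shows. Statements on the series, on what has been measured and on what is new or still open speak of the compounds shown alone.

Compound 1 `CCCSc1nc(N/N=C(\C)c2ccc(O)cc2)c2nnn(Cc3ccccc3)c2n1` and compound 2 `CCCSc1nc(N/N=C/c2ccc3ccccc3c2)c2nnn(Cc3ccccc3)c2n1` share one core and differ in the aryl group of the hydrazone. In a functional assay on MCF7 cells (Homo sapiens) for antiproliferative activity, read by MTT assay, with a stated time of 72 h (a higher number here means a weaker inhibitor, a lower number a stronger inhibitor), compound 1 gives 21600 nM. For compound 2 this assay records only a limit, > 64000 nM, so its activity is not fixed to a number. Compound 2 thus stands at the weak end of what is shown, at the limit of > 64000 nM in this assay, at which 1 of the 2 values shown sits. Compound 3 `CCCSc1nc(N/N=C/c2cccc(Cl)c2)c2nnn(Cc3ccccc3)c2n1` differs from compound 2 in one place: 3-chlorophenyl in place of naphthalen-2-yl on a carbon with a double bond to nitrogen. Among the compounds with values here, no measured pair shows what this change does to potency, so its size and direction are open. Compound 3 is expected to move back into the measurable range with a gain that is modest and uncertain, an at least 1.6-fold lower number from compound 2 to compound 3 (0.20 log units; that floor lies within the scatter). In this assay compound 3 is estimated at 40000 nM, within a range from 15000 nM to 110000 nM, with a real chance that only a limit is reported again.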

Compound 3, half-maximal inhibitory concentration: > 64000 nM
Compound 3: only a limit was reported; the forecaster's own chance of this, stated with the estimate: 45%; at least 1.6-fold (0.20 log units) between middle value and limit.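

Replacing naphthalen-2-yl with 3-chlorophenyl on a carbon with a double bond to nitrogen leaves compound 3, like compound 2, reported only as a limit: the limit of > 64000 nM in this assay, at which 2 of the 3 values shown sit.

Both values are limits, so the step between these two compounds cannot be read, and a smaller aryl group shows no measurable gain here. In this assay there is an at least 2.9-fold higher number from compound 1 to compound 3 (0.47 log units; beyond the scatter), which makes compound 1 the only compound shown with a measured number.

That step changes the whole group on a nitrogen on an aromatic ring, so it leaves open whether the hydroxyl or the methyl of compound 1 carries the difference. Also open, as far as these compounds go, is how a compound with an amine or a carboxylic acid on the aryl ring would behave on the shared core.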